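This account rests on a few compounds, and the source may have more. Where it says the series, first, only, none or still open, it means among the compounds named here.

Compound 3 `Cc1cn([C@@H]2O[C@H](CO[Si](C)(C)C(C)(C)C)[C@@]3(OS(=O)(=O)C=C3NCC(=O)C(=O)N3CCC3)[C@H]2O[Si](C)(C)C(C)(C)C)c(=O)n(C)c1=O` gives 84400 nM in a functional assay on HEL cells (Homo sapiens) (on this read-out higher numbers stand for lower toxicity in this test and lower numbers for higher toxicity in this test), and so holds the highest number among the three measured analogues; compound 1 `Cc1cn([C@@H]2O[C@H](CO[Si](C)(C)C(C)(C)C)[C@@]3(OS(=O)(=O)C=C3NC(=O)c3ccccc3)[C@H]2O[Si](C)(C)C(C)(C)C)c(=O)n(C)c1=O` gives 9700 nM and compound 2 `Cc1cn([C@@H]2O[C@H](CO[Si](C)(C)C(C)(C)C)[C@@]3(OS(=O)(=O)C=C3NC(N)=O)[C@H]2O[Si](C)(C)C(C)(C)C)c(=O)n(C)c1=O` gives 11000 nM. Compound 4 `Cc1cn([C@@H]2O[C@H](CO[Si](C)(C)C(C)(C)C)[C@@]3(OS(=O)(=O)C=C3NCC(N)=O)[C@H]2O[Si](C)(C)C(C)(C)C)c(=O)n(C)c1=O` differs from compound 3 in one place: amino in place of (azetidin-1-yl)carbonyl on a carbonyl carbon. The measured steps that bear on this are an 8.7-fold higher number from compound 1 to compound 3 (0.94 log units; beyond the scatter) and a 7.7-fold higher number from compound 2 to compound 3 (0.88 log units; beyond the scatter), both replacing a short carbonyl group on the amine nitrogen with the longer chain; compound 1 and compound 2 sit within the scatter of each other, as a 1.1-fold higher number from compound 1 to compound 2 (0.05 log units; within the scatter) shows. Shortening the chain again is therefore expected to move the number partly back toward compound 2, and for compound 4 a step of a 2.8-fold lower number from compound 3 to compound 4 (0.45 log units; beyond the scatter) is estimated, giving an expected value of 30000 nM with a range from 10000 nM to 90000 nM.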

Compound 4, half-maximal cytotoxic concentration: 13500 nM
The estimate for compound 4 lay 2.2-fold (0.35 log units) above the measured number; the measured number falls inside the stated range.
By their numbers in this assay, from the lowest: compounds 1, 2 and 4 (each within the scatter of the next); then compound 3.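

Carbamoylmethyl on the amine nitrogen does not by itself separate compound 4 from the shorter groups in this assay: a 1.2-fold higher number from compound 2 to compound 4 (0.09 log units; within the scatter) and a 1.4-fold higher number from compound 1 to compound 4 (0.14 log units; within the scatter) both lie within the scatter. The higher number of compound 3 therefore goes with the (azetidin-1-yl)carbonyl on the carbonyl carbon, as a 6.3-fold lower number from compound 3 to compound 4 (0.80 log units; beyond the scatter) shows when amino enters there. No evidence on the cause of this step is available.

Still open, going by these compounds, is whether the four-membered ring is required, or whether a pyrrolidin-1-yl or dimethylamino group on the same carbonyl would hold the higher number.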